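Turning the single stereocentre in a weak thiophene amide

The source may hold more compounds than are shown below. What is called first, only, known or untested is meant among the compounds shown, and "the series" means these compounds.

Two compounds share a core built from an ethyl-substituted amide bearing a thiophene methyl group. Compound 1, with the structure `CCN(Cc1cccs1)C(=O)COc1ccc(Cl)cc1`, and compound 2, with the structure `CCN(Cc1cccs1)C(=O)C[C@H](O)c1ccccc1`, were both tested in an assay on HEK293 cells for agonist activity at transient receptor potential cation channel subfamily M member 8 (Homo sapiens), read by fluorescence and calcium flux, with a stated time of 15 min; on this read-out higher numbers stand for an effect only at larger amounts of compound and lower numbers for an effect already at smaller amounts. Compound 1 gives 39 nM. Compound 2 gives 52000 nM, the highest of the two numbers, and it stands far from compound 1, beyond the usual scatter.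

Compound 3, with the structure `CCN(Cc1cccs1)C(=O)C[C@@H](O)c1ccccc1`, has not yet been tested in this assay. The difference from compound 2 is the two compounds have the same atoms and bonds and differ only in configuration as drawn: 1 of 1 stereo elements differ; a stereocentre at a saturated chain carbon is drawn S in compound 2 and R in compound 3. Mirror-image pairs of this kind can give nearly the same number or very different numbers, and nothing in the two measured compounds tells which way this pair will go. A modest improvement is therefore expected, as a step of a 2.6-fold lower number from compound 2 to compound 3 (0.41 log units; beyond the scatter), but with wide uncertainty. Compound 3 is thus expected to give about 20000 nM, with a plausible range from 2000 nM to 100000 nM.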

Compound 3, half-maximal effective concentration: "not active" (no number reported)
Nothing numeric was reported for compound 3; there is nothing to compare the estimate with.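

Within the data shown here, compound 3 is reported as "not active" in this assay, without a number, so no step from compound 2 to compound 3 can be read, even though the pair is closely matched: the fact that compounds 2 and 3 differ only in the configuration as drawn. The compounds shown leave open how far compound 3 lies from compound 2 and whether turning this one stereocentre changes the read-out at all.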